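A Second Chloro on the Aryl Ring of Compound 2

A few compounds are considered here, and "the series" means these few. Any claim that something is new, unique, unknown or untested is made for them only; others in the source may bear on it.

Compound 1 `COc1ccc(-c2cc3ccc(OCCCn4cc(CNC(=O)CCCCC5CCSS5)nn4)cc3oc2=O)cc1` — 42%
Compound 2 `O=C(CCCCC1CCSS1)NCc1cn(CCCOc2ccc3cc(-c4ccc(Cl)cc4)c(=O)oc3c2)nn1` — 40.9%

Of the compounds shown here, two have been measured in a functional assay on PC-12 cells (Rattus norvegicus) for cytotoxicity, read by MTT assay, with stated times of 3 h and 2 h, tested at 0.1 uM; a higher number here means a stronger effect of the compound at the concentration tested, a lower number a weaker effect. Compound 2 stands lowest of the two numbers, with compound 1 nearest: the step of a number 1.1 percentage points lower from compound 1 to compound 2 (within the scatter) is within the scatter, so the two read alike.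

Compound 3 `O=C(CCCCC1CCSS1)NCc1cn(CCCOc2ccc3cc(-c4ccc(Cl)c(Cl)c4)c(=O)oc3c2)nn1` has not yet been measured. It differs from compound 2 in one place: chloro in place of hydrogen on an aromatic carbon.

Within the data shown here, only one measured step bears on this change, and it is a loose fit: the replacement of methoxy by chloro on the same aromatic ring, from compound 1 to compound 2, moved the read-out by an amount within the scatter. Among the measured compounds shown here, no measured pair shows a chloro entering in place of hydrogen. On that basis a step of a number 0.1 percentage points higher from compound 2 to compound 3 (within the scatter) is expected, that is, none beyond the scatter. Compound 3 is therefore estimated at 41%, with a range from 30% to 52%.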

Compound 3, a percentage reported as activity, at one concentration (the size of the read-out at that concentration, not a potency): 38.1%
Compound 3: middle estimate off by 2.9 percentage points, on the high side, and the stated range covers the measured number.
By their numbers in this assay, from the lowest: compounds 3, 2 and 1 (each within the scatter of the next).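

In this assay, the effect of a chloro entering in place of hydrogen on this ring can now be read directly, and a second chloro, ortho to the first, gives a number 2.8 percentage points lower from compound 2 to compound 3 (within the scatter), so it leaves the read-out where the single chloro had it. The wider change from 4-methoxyphenyl to 3,4-dichlorophenyl reads the same way, with a number 3.9 percentage points lower from compound 1 to compound 3 (within the scatter), and the three aryl groups cannot be told apart at the tested concentration. Nothing measured here explains why these steps are so small.

As far as these compounds go, whether an amine or a carboxylic acid on this same aromatic carbon would move the read-out beyond the scatter remains open. Also open, from the compounds shown here alone, is whether these three compounds would still read alike at other concentrations, since a single concentration gives no potency.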